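This account rests on a few compounds, and the source may have more. Where it says the series, first, only, none or still open, it means among the compounds named here.

Measured in a functional assay (on this read-out higher numbers stand for weaker inhibition and lower numbers for stronger inhibition), are three compounds
Compound 1 `CC(C)=CCOc1ccc2c(c1)OC(c1ccccc1F)CC2=O` gives 6360 nM
Compound 2 `CC(C)=CCOc1ccc2c(c1)OC(c1cccc(Cl)c1)CC2=O` gives 6300 nM
Compound 3 `CC(C)=CCOc1ccc2c(c1)OC(c1ccccc1Br)CC2=O` gives 3180 nM

These three cannot be told apart on the numbers. The steps (a 1.0-fold lower number from compound 1 to compound 2 (0.00 log units; within the scatter)), (a 2.0-fold lower number from compound 1 to compound 3 (0.30 log units; within the scatter)) and (a 2.0-fold lower number from compound 2 to compound 3 (0.30 log units; within the scatter)) all lie within the scatter, so compound 3 stands level with the other two.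

Next comes compound 4 `CC(C)=CCOc1ccc2c(c1)OC(c1ccc(O)cc1)CC2=O` with 4-hydroxyphenyl in place of 2-bromophenyl on a saturated ring carbon, next to the ring oxygen (4-hydroxyphenyl in place of 2-bromophenyl on a saturated ring carbon). The measured steps that bear on this change are those swapping one halogen-bearing phenyl group for another, and all were small. None of them brings in a hydroxy group, so they offer only a loose guide. No step beyond the scatter is therefore expected in this assay in either direction, although the uncertainty is wide.

The expected move is small (a 1.6-fold higher number from compound 3 to compound 4 (0.20 log units; within the scatter)) and stays within the scatter. For compound 4 the estimated value is 5000 nM (expected range 1800 nM to 14000 nM)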

Compound 4, half-maximal inhibitory concentration: 6670 nM
For compound 4 the middle estimate is 1.3-fold (0.13 log units) below the measured one, and the stated range covers the measured number.
By their numbers in this assay, from the lowest: compounds 3, 2, 1 and 4 (each within the scatter of the next, the first and the last beyond it).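

In this assay, this carbon of the saturated ring, next to the ring oxygen, accepts a 4-hydroxyphenyl group, which brings in a hydrogen-bond donor and acceptor that the halogen-bearing phenyl groups lack, with little consequence for the read-out. Set against two of the earlier compounds the change stays within the scatter (a 1.1-fold higher number from compound 2 to compound 4 (0.02 log units; within the scatter)) and (a 1.0-fold higher number from compound 1 to compound 4 (0.02 log units; within the scatter)), and only against compound 3 does it pass the scatter, and then modestly (a 2.1-fold higher number from compound 3 to compound 4 (0.32 log units; beyond the scatter)). No measurement at hand accounts for that one modest step.

From the compounds shown here alone, how a 4-aminophenyl or 4-methoxyphenyl group would read at this carbon remains open. So does whether a 2-hydroxyphenyl group would match the 2-bromophenyl group of compound 3, since this change alters both the substituent and its place on the phenyl ring.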